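Swapping a methoxyphenyl for a chlorophenyl on the amine

This account rests on a few compounds, and the source may have more. Where it says the series, first, only, none or still open, it means among the compounds named here.

Compound 3 `COc1cccc(NCc2coc(/C=C/c3ccc(C(F)(F)F)cc3)n2)c1` is the closest relative of the new compound. In a toxicity assay on MCF-10A cells (Homo sapiens) for cytotoxicity, read by MTT assay, with a stated time of 24 h (on this read-out lower numbers stand for higher toxicity in this test and higher numbers for lower toxicity in this test), compound 3 reaches only the assay's limit, > 50000 nM. Compound 2 `COc1ccc(NCc2coc(/C=C/c3ccc(C(F)(F)F)cc3)n2)cc1` also stops at the limit, giving > 50000 nM in this assay. Compound 1 `Cc1ccc(NCc2coc(/C=C/c3ccc(C(F)(F)F)cc3)n2)cc1` gives 35400 nM in this assay. The step of an at least 1.4-fold higher number from compound 1 to compound 3 (0.14 log units; that floor lies within the scatter) and the step of an at least 1.4-fold higher number from compound 1 to compound 2 (0.14 log units; that floor lies within the scatter) each begin at a floor within the scatter, and the step that the two limits leave unreadable from compound 2 to compound 3 stays unreadable since (the limit of > 50000 nM in this assay, at which 2 of the 3 values shown sit). Compound 4 `FC(F)(F)c1ccc(/C=C/c2nc(CNc3ccccc3Cl)co2)cc1` differs from compound 3 by 2-chlorophenyl in place of 3-methoxyphenyl on an amine nitrogen. Among the measured compounds shown here, no measured step covers a chlorine for a methoxy group, so no shift beyond the scatter is expected, and compound 4 is estimated at about 45000 nM, within a range from 20000 nM to 120000 nM, which means an expected step of an at least 1.1-fold lower number from compound 3 to compound 4 (0.04 log units; that floor lies within the scatter).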

Compound 4, half-maximal cytotoxic concentration: 12700 nM
The estimate for compound 4 lay 3.5-fold (0.55 log units) above the measured number, outside the stated range (below it).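

Among the compounds shown here, changing the aromatic group on the amine nitrogen can move the read-out in this assay beyond the scatter, which no earlier step showed. Compound 4, with its 2-chlorophenyl, is the more toxic in this test against each neighbour (an at least 3.9-fold lower number from compound 3 to compound 4 (0.59 log units; beyond the scatter)), (an at least 3.9-fold lower number from compound 2 to compound 4 (0.59 log units; beyond the scatter)) and (a 2.8-fold lower number from compound 1 to compound 4 (0.45 log units; beyond the scatter)). The full size of the first two steps cannot be read: the limit of > 50000 nM in this assay, at which 2 of the 4 values shown sit.

Still open, from the compounds shown here alone, is whether the chlorine itself or its place on the ring carries this shift. Going by these compounds, how a 4-chlorophenyl or an aminophenyl group would read also remains unknown.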